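Heteroaryl replacement on the amide nitrogen of a TRPM8 agonist

The source may report more compounds than this note shows. Statements on the series, on what has been measured and on what is new or still open speak of the compounds shown alone.

Compound 1 `Cc1ccc(OCC(=O)N(Cc2cccs2)c2c(C)n[nH]c2C)cc1`: 0.3 nM
Compound 2 `Cc1ccc(OCC(=O)N(Cc2cccs2)c2ccn(C)n2)cc1`: 855 nM
Compound 3 `Cc1ccc(OCC(=O)N(Cc2cccs2)c2ccon2)cc1`: 2 nM

In an assay on HEK293 cells for agonist activity at transient receptor potential cation channel subfamily M member 8 (Homo sapiens), read by fluorescence and calcium flux, with a stated time of 15 min (on this read-out higher numbers stand for an effect only at larger amounts of compound and lower numbers for an effect already at smaller amounts), compound 3 stands second highest of the three numbers, its nearest neighbour being compound 1 with a 6.7-fold higher number from compound 1 to compound 3 (0.82 log units; beyond the scatter), its furthest compound 2 with a 430-fold lower number from compound 2 to compound 3 (2.63 log units; beyond the scatter). Compound 4 `Cc1ccc(OCC(=O)N(Cc2cccs2)c2ccccn2)cc1` differs from compound 3 by pyridin-2-yl in place of 1,2-oxazol-3-yl on an amide-type nitrogen. Going by the values given here, no measured step exchanges a five-membered ring for a six-membered one here, but the two steps that touch this position, a 2900-fold higher number from compound 1 to compound 2 (3.45 log units; beyond the scatter) and a 430-fold lower number from compound 2 to compound 3 (2.63 log units; beyond the scatter), show that this assay is very sensitive to the group on the amide nitrogen. A step beyond the scatter is therefore expected, most likely toward a higher number, giving a 10-fold higher number from compound 3 to compound 4 (1.00 log units; beyond the scatter). For compound 4 the estimate is 20 nM, within 2 nM to 200 nM.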

Compound 4, half-maximal effective concentration: 200 nM
Beside the measured number, compound 4's estimate is 10-fold (1.00 log units) below it; low and high end bracket the measured number.
By their numbers in this assay, from the lowest: compound 1; then compound 3; then compound 4; then compound 2.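

With pyridin-2-yl on the amide-type nitrogen, this assay gives a 100-fold higher number from compound 3 to compound 4 (2.00 log units; beyond the scatter) and a 670-fold higher number from compound 1 to compound 4 (2.82 log units; beyond the scatter) but also a 4.3-fold lower number from compound 2 to compound 4 (0.63 log units; beyond the scatter) so the one six-membered ring shown falls inside the range spanned by the five-membered rings, and ring size alone does not set the number at this position. Nothing at hand says what lies behind these steps. The compounds shown leave open whether methyl groups on pyridin-2-yl, as on the 3,5-dimethyl-1H-pyrazol-4-yl of compound 1, would lower the number, and how a phenyl or pyrimidin-2-yl ring would compare.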